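The source may hold more compounds than are shown below. What is called first, only, known or untested is meant among the compounds shown, and "the series" means these compounds.

Measured compounds:
compound 1 `CC(C)(C)N(NC(=O)c1ccccc1)C(=O)c1ccccc1Br` gives 170 nM
compound 2 `CC(C)(C)N(NC(=O)c1ccccc1)C(=O)c1ccccc1C(F)(F)F` gives 631 nM

In an assay on cells for agonist activity at ecdysone receptor (Bombyx mori), read by a luciferase reporter, with a stated time of 24 h (on this read-out lower numbers stand for an effect already at smaller amounts and higher numbers for an effect only at larger amounts of compound), compound 1 holds the lower of the two numbers; compound 2 lies a 3.7-fold higher number from compound 1 to compound 2 (0.57 log units; beyond the scatter) away from it, and that step stands beyond the scatter, the change being trifluoromethyl in place of bromo on an aromatic carbon.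

Compound 3 `Cc1cc(C)cc(C(=O)N(NC(=O)c2ccccc2)C(C)(C)C)c1` has not been measured in this assay. It differs from compound 1 by 3,5-dimethylphenyl in place of 2-bromophenyl on a carbonyl carbon. Within the data shown here, only one measured step bears on this change: the step from compound 1 to compound 2 alters the same ring on the carbonyl carbon and moved the read-out by a 3.7-fold higher number from compound 1 to compound 2 (0.57 log units; beyond the scatter), a modest shift. The change to compound 3 is of a different kind, exchanging bromo for two methyl groups in a new arrangement, so the direction cannot be read from that single step. A step of roughly similar size is expected, in either direction, with a slight lean toward a lower number. Compound 3 is therefore estimated at 120 nM, within 30 nM to 500 nM, which corresponds to an expected 1.4-fold lower number from compound 1 to compound 3 (0.15 log units; within the scatter).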

Compound 3, half-maximal effective concentration: 69.2 nM
Compound 3: middle estimate off by 1.7-fold (0.24 log units), on the high side, and the stated range covers the measured number.
By their numbers in this assay, from the lowest: compound 3; then compound 1; then compound 2.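

Together with a 3.7-fold higher number from compound 1 to compound 2 (0.57 log units; beyond the scatter) in this assay, the new result, a 2.5-fold lower number from compound 1 to compound 3 (0.39 log units; beyond the scatter), shows that changes to the ring on this carbonyl carbon can lower the number as well as raise it. Bromo is therefore not required for a low number here: 3,5-dimethylphenyl, which contains carbon only, gives a lower number than the 2-bromophenyl it replaces. No supporting measurement shows why the number moved at this position.

Because compound 3 differs from compound 1 both in the groups on the ring and in their arrangement, the compounds shown cannot separate the loss of bromo from the gain of two methyl groups, and a ring bearing a single methyl group would be needed to begin to divide those contributions. Going by these compounds, it also remains open whether other groups on this ring, such as chloro or methoxy, would follow compound 3 or compound 1, and whether the lower number would persist with changes elsewhere in the shared core.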